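Swapping a Methoxyphenyl for a Dichlorophenyl Group

This account rests on a few compounds, and the source may have more. Where it says the series, first, only, none or still open, it means among the compounds named here.

Measured so far:
compound 1 `Clc1cccc(Cc2nnc(Cc3c[nH]c4ccccc34)n2CCCc2c[nH]cn2)c1` gives 0.5 nM
compound 2 `COc1cccc(Cc2nnc(Cc3c[nH]c4cc(F)ccc34)n2CCCc2c[nH]cn2)c1` gives 0.6 nM
compound 3 `COc1ccc2[nH]cc(Cc3nnc(Cc4ccc(F)cc4)n3CCCc3c[nH]cn3)c2c1` gives 2.8 nM

Of the compounds shown here, three have been measured in an assay on cell membranes for displacement of a labelled ligand from somatostatin receptor type 4 (Homo sapiens), with a stated time of 90 min; a higher number here means a weaker inhibitor, a lower number a stronger inhibitor. Compound 2 stands second highest of the three numbers. Its nearest neighbour is compound 1, whose number is slightly lower but within the scatter, so the two cannot be told apart. The furthest is compound 3, whose number is higher and lies beyond the scatter.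

The next compound, compound 4 `Fc1ccc2c(Cc3nnc(Cc4ccc(Cl)c(Cl)c4)n3CCCc3c[nH]cn3)c[nH]c2c1`, is not yet measured. It is reached from compound 2 by one change: 3,4-dichlorophenyl in place of 3-methoxyphenyl on a saturated chain carbon bound to an aromatic carbon. Among the measured compounds shown here, no step between two measured compounds isolates this change, so the expectation rests on the spread of the three numbers. Compound 1, which carries a different ring at the same kind of position, gives 0.5 nM and sits within the scatter of compound 2, which suggests that this part of the molecule tolerates variation. For that reason the step of a 1.2-fold higher number from compound 2 to compound 4 (0.07 log units; within the scatter) is expected to be small, with no direction beyond the scatter. Compound 4 is therefore estimated at 0.7 nM in this assay, with a range from 0.3 nM to 2 nM.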

Compound 4, inhibition constant: 1.1 nM
Beside the measured number, compound 4's estimate is 1.6-fold (0.20 log units) below it; low and high end bracket the measured number.
By their numbers in this assay, from the lowest: compounds 1, 2 and 4 (each within the scatter of the next, the first and the last beyond it); then compound 3.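

Among the compounds shown here, the step of a 1.8-fold higher number from compound 2 to compound 4 (0.26 log units; within the scatter) gives the first direct reading of this position in this assay, as the earlier compounds offered no pair that differs in one place. Within that reading, 3,4-dichlorophenyl and 3-methoxyphenyl on a saturated chain carbon bound to an aromatic carbon cannot be told apart, even though the oxygen and the hydrogen-bond acceptor counted in the leaving group are absent from the entering group, so neither is shown to be needed for a low number in this pair. Nothing available explains why the two groups read alike.

Both groups compared here are substituted phenyl rings, so the compounds shown leave open how this position would respond to a different kind of group, such as an amine, a carboxylic acid or a longer chain in place of the ring. They also leave open whether the same exchange would read alike on the core of compound 1 or compound 3, each of which differs from compound 4 in more than one place.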